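The source may hold more compounds than are shown below. What is called first, only, known or untested is meant among the compounds shown, and "the series" means these compounds.

Compound 3, `C=C1CC[C@@H]2[C@](C)(COC(C)=O)[C@H](O)CC[C@@]2(C)[C@@H]1C/C=C1/C(=O)OC[C@@H]1Oc1c(Cl)cc(Cl)c2cccnc12`, is one of three compounds tested in an ADME assay on SNB-19 cells (Homo sapiens) for cytotoxicity, read by MTT assay, with a stated time of 24 h; on this read-out higher numbers stand for lower toxicity in this test and lower numbers for higher toxicity in this test. In this assay compound 3 gives 39300 nM, the lowest of the three numbers. Compound 2, `C=C1CC[C@@H]2[C@](C)(CO)[C@H](O)CC[C@@]2(C)[C@@H]1C/C=C1/C(=O)OC[C@@H]1Oc1ccnc2ccccc12`, gives 61200 nM in this assay, a number that sits within the scatter of compound 3. Compound 1, `C=C1CC[C@@H]2[C@](C)(CO)[C@H](O)CC[C@@]2(C)[C@@H]1C/C=C1/C(=O)OC[C@H]1Oc1c(Cl)cc(Cl)c2cccnc12`, gives 85200 nM in this assay, and that number lies beyond the scatter above compound 3. Among the compounds with values here, no single-change pair stands among the measured compounds, so no measured step can be given.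

Compound 4, `C=C1CC[C@@H]2[C@](C)(CO)[C@H](O)CC[C@@]2(C)[C@@H]1C/C=C1/C(=O)OC[C@@H]1Oc1c(Cl)cc(Cl)c2cccnc12`, has not been measured in this assay. It differs from compound 3 as follows: hydrogen in place of acetyl on an oxygen on a saturated carbon. Compound 1 and compound 2 both carry the hydroxymethyl group that compound 4 carries, and both gave higher numbers than compound 3, with compound 1 beyond the scatter and compound 2 within it. On that ground the step is expected to run upward, though it may well stay within the scatter, and the expected step is a 1.8-fold higher number from compound 3 to compound 4 (0.25 log units; within the scatter). Compound 4 is therefore estimated to give 70000 nM in this assay, with a range from 35000 nM to 140000 nM.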

Compound 4, half-maximal cytotoxic concentration: > 100000 nM
Compound 4: only a limit was reported (the forecaster's own chance of this, stated with the estimate: 10%); middle value at least 1.4-fold (0.15 log units) away from the limit.
By their numbers in this assay, from the lowest: compounds 3, 2 and 1 (each within the scatter of the next, the first and the last beyond it). At a limit, above all of these: compound 4.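

In this assay, within the data shown here, hydrogen in place of acetyl on an oxygen on a saturated carbon gives the first readable step at this position: an at least 2.5-fold higher number from compound 3 to compound 4 (0.40 log units; beyond the scatter), so on this otherwise unchanged compound the change from acetoxymethyl to hydroxymethyl goes with lower toxicity in this test. The other two steps are less decisive, since 5,7-dichloroquinolin-8-yl in place of quinolin-4-yl on an oxygen on a saturated carbon gives an at least 1.6-fold higher number from compound 2 to compound 4 (0.21 log units; that floor lies within the scatter), and the change of configuration gives an at least 1.1-fold higher number from compound 1 to compound 4 (0.06 log units; that floor lies within the scatter), so neither step establishes a real difference. All three steps rest on a limit for compound 4 and not on a number, which makes each of them a floor: the limit of > 100000 nM in this assay, at which 1 of the 4 values shown sits.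

The compounds shown leave open whether a methyl ether or a butanoyl ester on this oxygen would behave like the acetyl of compound 3 or like the hydroxy of compound 4. They also leave open how far compound 4 truly lies from its limit, and whether the acetyl step would carry over to a compound with quinolin-4-yl.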